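Bulkier amine on the side chain of compound 2

A few compounds are considered here, and "the series" means these few. Any claim that something is new, unique, unknown or untested is made for them only; others in the source may bear on it.

Compound 1 `CCN(C)CCCOc1ccc2cc(NC(=O)c3ccc(O)c(CC=C(C)C)c3)c(=O)oc2c1C` gives 2190 nM in a functional assay on MCF7 cells (Homo sapiens) for antiproliferative activity; on this read-out higher numbers stand for weaker inhibition and lower numbers for stronger inhibition.
Compound 2 `CCN(CC)CCCOc1ccc2cc(NC(=O)c3ccc(O)c(CC=C(C)C)c3)c(=O)oc2c1C` gives 6390 nM in this assay.

For the measured compounds named here, compound 2 stands at the higher of the two numbers in this assay, and its only neighbour is compound 1, from which it differs by a 2.9-fold higher number from compound 1 to compound 2 (0.47 log units; beyond the scatter). Compound 3 `CC(C)=CCc1cc(C(=O)Nc2cc3ccc(OCCCN(C(C)C)C(C)C)c(C)c3oc2=O)ccc1O` carries diisopropylamino in place of diethylamino on a saturated chain carbon, three bonds along the chain from an oxygen on an aromatic ring. Going by the values given here, the one step at hand bears directly on this change, since the same kind of growth on the carbons bound to the amine nitrogen already gave a 2.9-fold higher number from compound 1 to compound 2 (0.47 log units; beyond the scatter). A further step in the same direction is therefore expected for compound 3, of a size estimated as a 2.5-fold higher number from compound 2 to compound 3 (0.40 log units; beyond the scatter), reaching beyond the scatter. Compound 3 is accordingly estimated at 16000 nM in this assay, with a range from 6000 nM to 45000 nM, though this rests on a single measured step.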

Compound 3, half-maximal inhibitory concentration: 1310 nM
Estimate against measurement, compound 3: 12-fold (1.09 log units) above; measured number outside the range, below it.
By their numbers in this assay, from the lowest: compounds 3 and 1 (each within the scatter of the next); then compound 2.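

In this assay, the change to diisopropylamino reverses the direction of the earlier step on this side chain: a 2.9-fold higher number from compound 1 to compound 2 (0.47 log units; beyond the scatter) was followed by a 4.9-fold lower number from compound 2 to compound 3 (0.69 log units; beyond the scatter) on going to the group with more heavy atoms. Set against the first amine, the same position gives a 1.7-fold lower number from compound 1 to compound 3 (0.22 log units; within the scatter) and so leaves ethyl(methyl)amino and diisopropylamino indistinguishable, with diethylamino alone standing apart among the three, so size of the amine substituents does not order these numbers. Nothing available explains why diethylamino stands apart.

On these data alone, it remains open whether dimethylamino or a cyclic amine such as piperidine or morpholine would group with compound 1 and compound 3 or with compound 2. It is also open whether the same pattern among these amines would hold on a butyl chain in place of the propyl chain.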